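Swapping Fluorine for Bromine on the Benzyl Ring

The compounds below may be only part of what the source reports. "The series", "measured", "known", "first", "only" and "open" are said of these compounds alone.

The shared core of compound 3 carries a benzylamine arm, and compound 3 `O=c1cc(CNCc2cccc(F)c2)oc2ccc(O)c(O)c12` bears a fluoro group on the benzyl ring. In an ADME assay on Huh-7 cells (Homo sapiens) for cytotoxicity (on this read-out lower numbers stand for higher toxicity in this test and higher numbers for lower toxicity in this test), compound 3 gives > 100000 nM, which is a limit of the assay and not a number. Compound 1 `O=c1cc(CNCc2ccccc2)oc2ccc(O)c(O)c12` lacks any halogen, and in this assay compound 1 gives > 100000 nM, again only a limit. Compound 2 `O=c1cc(CNCc2ccccc2Br)oc2ccc(O)c(O)c12` carries a bromo group instead, and in this assay compound 2 gives > 100000 nM, also a limit. The steps a step that the two limits leave unreadable from compound 1 to compound 2, a step that the two limits leave unreadable from compound 1 to compound 3 and a step that the two limits leave unreadable from compound 2 to compound 3 therefore cannot be sized, because of the limit of > 100000 nM in this assay, at which 3 of the 3 values shown sit.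

Compound 4 `O=c1cc(CNCc2cccc(Br)c2)oc2ccc(O)c(O)c12` differs from compound 3 in one place: bromo in place of fluoro on an aromatic carbon. The nearest comparison is the bromo addition from compound 1 to compound 2, which stayed at the limit. Compound 4 is therefore expected to give 100000 nM, with a range from 40000 nM to 250000 nM. The expected step is a number no higher from compound 3 to compound 4 (the limit leaves the size open), most likely again reported only as a limit.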

Compound 4, half-maximal cytotoxic concentration: > 100000 nM
Compound 4: only a limit was reported; the forecaster's own chance of this, stated with the estimate: 85%; the middle value sits exactly at the limit.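

No step between compound 1, compound 2, compound 3 and compound 4 can be read in this assay, because each of the four compounds gives only a limit of the assay and not a number: the limit of > 100000 nM in this assay, at which 4 of the 4 values shown sit.

The compounds shown leave open whether hydrogen, fluoro or bromo on the benzyl ring makes any difference to cytotoxicity, and at what concentration, if any, these compounds harm the cells.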